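The compounds below may be only part of what the source reports. "The series", "measured", "known", "first", "only" and "open" are said of these compounds alone.

Measured compounds:

Compound 1 `CCCCCC1(O)C(=O)Nc2ccc(Nc3ccc(F)cc3)cc21` gives > 100000 nM in a functional assay on NCI-H460 cells (Homo sapiens) for antiproliferative activity, read by MTT assay, with a stated time of 48 h; on this read-out higher numbers stand for weaker inhibition and lower numbers for stronger inhibition; this value is a limit of the assay, not a number.
Compound 2 `CCCCCCC1(O)C(=O)Nc2ccc(Nc3ccc(F)cc3)cc21` gives 50700 nM in this assay.
Compound 3 `CCCCC1(O)C(=O)Nc2ccc(Nc3ccc(Cl)cc3)cc21` gives 24400 nM in this assay.

The change from compound 1 to compound 2 is methyl in place of hydrogen on a saturated chain carbon, five bonds along the chain from a saturated ring carbon. It yielded an at least 1.9-fold lower number from compound 1 to compound 2 (0.29 log units; that floor lies within the scatter), and the floor of that step rests on compound 1 sitting at the limit of > 100000 nM in this assay, at which 1 of the 3 values shown sits. Compound 3 has the lowest number among the two numbers measured; its nearest neighbour is compound 2, a gap beyond the scatter. How the core of compound 1 differs from the core of compound 3 is not broken down here.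

Compound 4 `CCCCCC1(O)C(=O)Nc2ccc(Nc3ccc(Cl)cc3)cc21` is still to be measured. It differs from compound 3 by methyl in place of hydrogen on a saturated chain carbon, four bonds along the chain from a saturated ring carbon. The place is not word for word the same as before: here the carbon lies four bonds along the chain from a saturated ring carbon, rather than five, so this is the same kind of change, not the same one. Resting on an at least 1.9-fold lower number from compound 1 to compound 2 (0.29 log units; that floor lies within the scatter), a step of similar size is expected from compound 3 to compound 4, namely a 1.7-fold lower number from compound 3 to compound 4 (0.24 log units; within the scatter), in this assay. Compound 4 is therefore estimated at 14000 nM, between 6000 nM and 40000 nM.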

Compound 4, half-maximal inhibitory concentration: 40800 nM
For compound 4 the middle estimate is 2.9-fold (0.46 log units) below the measured one, outside the stated range (above it).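

In this assay, methyl in place of hydrogen on the chloro-bearing core gave a 1.7-fold higher number from compound 3 to compound 4 (0.22 log units; within the scatter), while chloro in place of fluoro gave an at least 2.4-fold lower number from compound 1 to compound 4 (0.38 log units; beyond the scatter). The methyl step did not carry over as a fixed amount from one core to the other: the same change on two cores in this assay, an at least 1.9-fold lower number (0.29 log units; that floor lies within the scatter) from compound 1 to compound 2 and a 1.7-fold higher number (0.22 log units; within the scatter) from compound 3 to compound 4, at least 3.2-fold (0.51 log units) apart, beyond the scatter of two such steps

Compound 1 gives > 100000 nM, a limit of the assay and not a number, so the gap between the two steps is only a floor; neither step on its own shows a change of direction, and this single pair of cores shows nothing about how the change would behave on any other core.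

The compounds shown leave open how a longer chain would read on either core, and whether the gap between the two cores would persist along such a chain. They also leave open what a bromo or a methoxy group in place of the chloro would give in this assay.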